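A few compounds are considered here, and "the series" means these few. Any claim that something is new, unique, unknown or untested is made for them only; others in the source may bear on it.

Of the compounds shown here, two of one series have been tested so far in a functional assay on EKVX cells (Homo sapiens) for cytotoxicity, read by sulforhodamine B assay, with a stated time of 48 h, tested at 10 uM; on this read-out lower numbers stand for a stronger effect and higher numbers for a weaker effect at the one concentration tested. Compound 1, `COc1cc(C)cc(-c2c(-c3ccnc(-c4ccc(C(C)=O)cc4)c3)cnn2CC#N)c1`, gives 46% in this assay. Compound 2, `COc1cc(C)cc(-c2nn(CC#N)cc2-c2ccc(-c3cccc(C(C)=O)c3)nc2)c1`, gives -10% in this assay. Of the two numbers, compound 1 stands as the higher one, with the gap to compound 2 lying beyond the usual scatter, so compound 1 shows the weaker effect of the pair.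

A third compound, compound 3, `COc1cc(C)cc(-c2c(-c3ccnc(-c4ccc(N(C)C)cc4)c3)cnn2CC#N)c1`, has not yet been measured in this assay. It differs from compound 1 in one place: dimethylamino in place of acetyl on an aromatic carbon. Within the data shown here, no measured pair in this set shows what such a change does, so the expectation rests on the two numbers alone, and on the fact that the rest of the molecule stays as it is in compound 1.

The step from compound 1 to compound 3 is expected to be small, with no clear direction and likely within the scatter, at a number 4 percentage points higher from compound 1 to compound 3 (within the scatter). On that basis compound 3 is estimated to give 50% in this assay, in a range from 20% to 85%.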

Compound 3, a percentage reported as activity, at one concentration (the size of the read-out at that concentration, not a potency): 2%
Beside the measured number, compound 3's estimate is 48 percentage points above it; measured number outside the range, below it.
By their numbers in this assay, from the lowest: compound 2; then compound 3; then compound 1.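

In this assay, putting dimethylamino in place of acetyl on the outer phenyl ring gives a number 44 percentage points lower from compound 1 to compound 3 (beyond the scatter), so this position is far from indifferent to what it carries, and a single swap here markedly strengthens the effect at the one concentration tested. The computed counts for the two groups match in heavy atoms, hydrogen-bond donors, hydrogen-bond acceptors and net charge, so those counts do not separate them; on paper, the differences are the loss of the carbonyl double bond and nitrogen standing in place of oxygen. Nothing measured here on either group accounts for the size of this step.

A primary amine, a methoxy group or a carboxylic acid at the same place would help show whether the step belongs to dimethylamino itself or simply to the loss of acetyl. From the compounds shown here alone, it also remains open whether the same swap would act in the same way on compound 2, which carries its acetyl in a different arrangement.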